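Ethynyl in Place of Ethyl at the Assay Limit

The compounds below may be only part of what the source reports. "The series", "measured", "known", "first", "only" and "open" are said of these compounds alone.

compound 1, `Cc1ccc(-c2cc(C)oc(=O)c2)cc1`, > 50000 nM
compound 2, `CCc1cc(C)oc(=O)c1`, > 50000 nM

Both measured compounds were examined in a functional assay on A2780 cells (Homo sapiens) for inhibition; a higher number here means a weaker inhibitor, a lower number a stronger inhibitor. Compound 1 `Cc1ccc(-c2cc(C)oc(=O)c2)cc1` returns only a limit of the assay, > 50000 nM. Compound 2 `CCc1cc(C)oc(=O)c1` likewise returns only a limit, > 50000 nM. Among the measured compounds shown here, compound 2 thus stands at the limit itself, and the one further value shown is a limit too, as the limit of > 50000 nM in this assay, at which 2 of the 2 values shown sit, records. For the measured compounds named here, no two measured compounds differ in a single place, so no step between them can be stated. Compound 3 `C#Cc1cc(C)oc(=O)c1` differs from compound 2 by ethynyl in place of ethyl on an aromatic carbon. Going by the values given here, with no measured step to lean on and both measured compounds sitting at the limit, the expected step is none beyond the scatter, a step that the limit leaves unreadable from compound 2 to compound 3. Compound 3 is therefore estimated at 60000 nM, with a range from 20000 nM to 200000 nM, and this assay is expected most likely to report only a limit once more.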

Compound 3, half-maximal inhibitory concentration: 3100 nM
The estimate for compound 3 lay 19-fold (1.29 log units) above the measured number; measured number outside the range, below it.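

In this assay, ethynyl in place of ethyl on this aromatic carbon, opposite the ring oxygen, gives an at least 16-fold lower number from compound 2 to compound 3 (1.20 log units; beyond the scatter), so this position can respond to a change of a single group. The leaving and entering groups both hold 2 heavy atoms, and what enters is 1 triple bond outside aromatic rings, so a change of that kind, with no added heavy atoms, is enough to bring the read-out away from the limit. The full size of the step cannot be read, because compound 2 gives only a limit: the limit of > 50000 nM in this assay, at which 2 of the 3 values shown sit.

The compounds shown leave open whether a nitrile, a vinyl group or a longer alkyne chain at this place would give a similar result. They also leave open whether the methyl group shared by compound 2 and compound 3 contributes to it.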